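The source may report more compounds than this note shows. Statements on the series, on what has been measured and on what is new or still open speak of the compounds shown alone.

Measured compounds and their numbers:

Compound 1, `Cc1cc(Nc2cc(-c3ccccc3)[nH]n2)n2nc(SCc3ccc(Cl)cc3)nc2n1`: 8260 nM
Compound 2, `Cc1cc(Nc2cc(-c3ccccc3)[nH]n2)n2nc(SCc3ccc(Br)cc3)nc2n1`: 2720 nM

Both numbers come from a functional assay on MCF7 cells (Homo sapiens) for inhibition, read by MTT assay, with a stated time of 72 h; a lower number here means a stronger inhibitor, a higher number a weaker inhibitor. Going by the values given here, compound 2 holds the lowest of the two values shown, with compound 1 as its only neighbour; the one measured step, a 3.0-fold lower number from compound 1 to compound 2 (0.48 log units; beyond the scatter), lies beyond the scatter and is the only step in the set.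

Compound 3, `COc1ccc(CSc2nc3nc(C)cc(Nc4cc(-c5ccccc5)[nH]n4)n3n2)cc1`, is unmeasured. Its change from compound 2 is methoxy in place of bromo on an aromatic carbon, on an aromatic carbon of the six-membered aromatic ring of carbon only, para to a large group. Among the compounds with values here, no measured step bears directly on a methoxy at this place: the single step known concerns bromo in place of chloro, and it moved the number only modestly. Within the data shown here, with bromo leaving and methoxy entering, and no measured compound carrying a methoxy anywhere, the direction cannot be taken from the data with confidence. A step of roughly the size of the known one, toward a higher number, is expected, with the step of a 2.0-fold higher number from compound 2 to compound 3 (0.31 log units; beyond the scatter) as the central guess. Compound 3 is therefore estimated at 5500 nM, within a range from 1800 nM to 17000 nM in this assay.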

Compound 3, half-maximal inhibitory concentration: 4020 nM
Compound 3: middle estimate off by 1.4-fold (0.14 log units), on the high side, and the stated range covers the measured number.
By their numbers in this assay, from the lowest: compounds 2 and 3 (each within the scatter of the next); then compound 1.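

In this assay, going by these compounds alone, methoxy in place of bromo on the aromatic carbon gives a 1.5-fold higher number from compound 2 to compound 3 (0.17 log units; within the scatter) and is the first change here to a group that is not a halogen. Compound 2 and compound 3 therefore cannot be told apart, although the entering group has one more heavy atom than the one leaving and adds a hydrogen-bond acceptor. Methoxy in place of chloro gives a 2.1-fold lower number from compound 1 to compound 3 (0.31 log units; beyond the scatter), which, together with the bromo and methoxy pair, leaves compound 1 as the only one of the three standing apart, though only modestly; nothing measured on these compounds explains this.

The compounds shown leave open whether this place accepts groups of a different kind, such as an amine, a carboxylic acid or a longer alkoxy chain, with a step beyond the scatter in either direction. They also leave open whether the shared core would respond in the same way if the (4-methoxybenzyl)sulfanyl group were replaced by an unsubstituted benzylsulfanyl group or by a plain methylsulfanyl group.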